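Removing the amide methyl of compound 2: working notes

This account rests on a few compounds, and the source may have more. Where it says the series, first, only, none or still open, it means among the compounds named here.

Measured so far:
compound 1 `Clc1cccc(Nc2nccc(-c3cccnc3)n2)c1` — 1500 nM
compound 2 `CC(=O)N(C)c1ccc(Nc2nccc(-c3cccnc3)n2)cc1` — 900 nM
compound 3 `CC(=O)N(C)c1ccc(Nc2nccc(-c3ccccn3)n2)cc1` — 1800 nM

Three analogues on a shared core have been measured in a functional assay for inhibition, with Homo sapiens as the target; on this read-out higher numbers stand for weaker inhibition and lower numbers for stronger inhibition. Compound 2 gives the lowest of the three numbers in this assay, but its gap to compound 1 and its gap to compound 3 both fall within the scatter, so no ordering among the three is claimed. Among the measured compounds shown here, the only single-point step among the measured compounds, a 2.0-fold higher number from compound 2 to compound 3 (0.30 log units; within the scatter), concerns the pyridyl attachment rather than the amide and itself stays within the scatter.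

Compound 4 `CC(=O)Nc1ccc(Nc2nccc(-c3cccnc3)n2)cc1` differs from compound 2 by hydrogen in place of methyl on an amide-type nitrogen. For the measured compounds named here, no measured pair isolates this change, so nothing can be carried over directly; the one step measured on the series was within the scatter, and the amide region has so far given no signal at all. The expectation is therefore no step beyond the scatter, no change at the digits printed from compound 2 to compound 4 (within the scatter). Compound 4 is expected to give about 900 nM in this assay, within a range of 400 nM to 2000 nM.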

Compound 4, half-maximal inhibitory concentration: 3600 nM
Compound 4: the middle estimate sits 4.0-fold (0.60 log units) below what was measured; measured number outside the range, above it.
By their numbers in this assay, from the lowest: compounds 2, 1, 3 and 4 (each within the scatter of the next, the first and the last beyond it).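

In this assay, among the compounds shown here, the change to hydrogen in place of methyl on the amide-type nitrogen gives a 4.0-fold higher number from compound 2 to compound 4 (0.60 log units; beyond the scatter) and is the only single-place step that lies beyond the scatter. For the compounds shown here, the other step, a 2.0-fold higher number from compound 2 to compound 3 (0.30 log units; within the scatter) and concerning the pyridyl attachment, gave no such signal, so the amide nitrogen is the one place so far where the read-out clearly responds, with the methyl-bearing compound 2 giving the stronger inhibition of this pair. The data shown offer no measured explanation for this step.

From the compounds shown here alone, what an ethyl or a longer chain on this nitrogen would give remains open, so it is unknown whether methyl is the preferred group there. Also open, going by these compounds, is whether the same hydrogen-for-methyl change gives a similar step with pyridin-2-yl on the shared core.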